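The source may report more compounds than this note shows. Statements on the series, on what has been measured and on what is new or still open speak of the compounds shown alone.

Measured so far in a functional assay on MCF7 cells (Homo sapiens) for inhibition, read by MTT assay, with a stated time of 72 h; a lower number here means a stronger inhibitor, a higher number a weaker inhibitor:
compound 1 `COc1ccc(Cn2cc(CSC(=S)N3CCNCC3)nn2)cc1`: "not determined" (no result reported)
compound 2 `O=C(OCc1ccccc1)N1CCN(C(=S)SCc2cn(Cc3ccc(F)cc3)nn2)CC1`: 10300 nM
compound 3 `COc1cc(Cn2cc(CSC(=S)N3CCNCC3)nn2)cc(OC)c1OC`: "not determined" (no result reported)

Within the data shown here, compound 2 is the only entry with a number in this assay; compound 1 and compound 3 carry no result, so compound 2 stands alone and cannot be ranked against them. Compound 4 `COc1ccc(Cn2cc(CSC(=S)N3CCN(C(=O)OCc4ccccc4)CC3)nn2)cc1` is still to be measured. It differs from compound 2 in one place: methoxy in place of fluoro on an aromatic carbon. Among the measured compounds shown here, no pair of measured compounds differing in a single place is available, so no measured step guides the expectation. The step from compound 2 to compound 4 is expected to be a 1.0-fold lower number from compound 2 to compound 4 (0.01 log units; within the scatter), in no set direction and not beyond the usual scatter. Compound 4 is therefore estimated at 10000 nM, with a range from 4000 nM to 25000 nM.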

Compound 4, half-maximal inhibitory concentration: 30500 nM
Beside the measured number, compound 4's estimate is 3.1-fold (0.48 log units) below it; the whole stated range lies below it.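

In this assay, among these compounds, the change from 4-fluorobenzyl to 4-methoxybenzyl gives a 3.0-fold higher number from compound 2 to compound 4 (0.47 log units; beyond the scatter) and is the first single-place step available. It shows that this aromatic carbon responds to its substituent, with methoxy the weaker of the two groups tested here. Nothing measured accounts for the step.

From the compounds shown here alone, two groups define no trend, so it remains open whether a hydroxyl, a chlorine or a trifluoromethyl on this carbon would track fluoro or methoxy. Whether the step persists with other changes to the shared core is also unresolved.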